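N-Ethyl Homologue of Compound 2 in the Receptor Binding Series

This account rests on a few compounds, and the source may have more. Where it says the series, first, only, none or still open, it means among the compounds named here.

Measured so far:
compound 1 `CCC(=O)NC[C@@H]1CN(C)c2ccccc2[C@@H]1c1ccccc1` 0.48 nM
compound 2 `CC(=O)NCC1Cc2ccccc2N(C)C1` 15 nM

Two compounds have numbers in an assay on cells for displacement of a labelled ligand from melatonin receptor type 1B (Homo sapiens), read by filter binding, with a stated time of 120 min; a lower number here means a stronger inhibitor, a higher number a weaker inhibitor. Compound 1 gives 0.48 nM and compound 2 gives 15 nM. Compound 2 thus holds the higher of the two numbers; compound 1 sits well below it, and the gap between the two values lies beyond the scatter. The two structures differ in several places at once, so the gap cannot be tied to any one change.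

Compound 3 `CCN1CC(CNC(C)=O)Cc2ccccc21` is not yet measured. Its difference from compound 2 is a single one: methyl in place of hydrogen on a saturated chain carbon bound to a nitrogen on an aromatic ring in a ring; the same difference, cut one bond further out, reads methyl to ethyl. Within the data shown here, no step of this kind between measured compounds is available in this assay, so there is nothing to point the direction. The change is small in count and sits on the nitrogen substituent, away from the amide side chain shared by compound 2 and compound 3.

On that basis the expected step from compound 2 to compound 3 is no change at the digits printed from compound 2 to compound 3 (within the scatter), that is, no step beyond the scatter in either direction. Compound 3 is accordingly estimated at 15 nM, with a range from 5 nM to 45 nM.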

Compound 3, inhibition constant: 1 nM
Beside the measured number, compound 3's estimate is 15-fold (1.18 log units) above it; the measured number lies below the stated range.
By their numbers in this assay, from the lowest: compound 1; then compound 3; then compound 2.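

Working notes on the nitrogen substituent: in this assay, methyl in place of hydrogen on a saturated chain carbon bound to a nitrogen on an aromatic ring in a ring gives a 15-fold lower number from compound 2 to compound 3 (1.18 log units; beyond the scatter) and counts as a large step. Among these compounds, this is the first step that can be tied to one place, since the earlier pair differed in several places at once and could not show what any single change does. It shows that this position responds strongly to a very small change, as the step from methyl to ethyl adds one carbon and no ring, hydrogen-bond donor, hydrogen-bond acceptor or net charge, yet moves the number beyond the scatter; nothing at hand gives a reason for the size of this step.

The compounds shown leave open whether the trend continues, levels off or reverses with a longer chain such as n-propyl, a branched group such as isopropyl, or a ring-bearing group such as cyclopropylmethyl at this place. They also leave open whether ethyl in place of methyl would give a step of similar size on the core of compound 1, which differs from compound 3 in several places.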